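The compounds below may be only part of what the source reports. "The series", "measured", "known", "first", "only" and "open" are said of these compounds alone.

Of the compounds shown here, two have so far been measured in an assay on brain for displacement of a labelled ligand from Neuronal acetylcholine receptor; alpha4/beta2 (Rattus norvegicus); a higher number here means a weaker inhibitor, a lower number a stronger inhibitor. Compound 1 `CN(C)C1(COc2cccnc2)CC1` gives 95 nM. Compound 2 `Cc1ccc(OCC2(N)CC2)cn1` gives 266 nM, the higher of the two numbers, and its gap to compound 1 lies beyond the usual scatter. Compound 3 `NC1(COc2ccc(Cl)nc2)CC1` has not been measured. It differs from compound 2 by chloro in place of methyl on an aromatic carbon. Among the measured compounds shown here, no measured pair shows this exchange, so its effect rests on the structures alone. A moderate fall in the number, probably beyond the scatter, is expected, with a step of a 2.7-fold lower number from compound 2 to compound 3 (0.42 log units; beyond the scatter). Compound 3 is accordingly estimated at 100 nM, within 30 nM to 350 nM.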

Compound 3, inhibition constant: 98 nM
For compound 3 the middle estimate is 1.0-fold (0.01 log units) above the measured one; the measured number falls inside the stated range.
By their numbers in this assay, from the lowest: compounds 1 and 3 (each within the scatter of the next); then compound 2.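

In this assay, the exchange of methyl for chloro on an aromatic carbon next to the ring nitrogen gives a 2.7-fold lower number from compound 2 to compound 3 (0.43 log units; beyond the scatter). Among the compounds shown here, this is the first measured pair that differs in one place, and it shows that the number responds to the group at this position, even though both groups count one heavy atom and neither adds a hydrogen-bond donor or acceptor. No measurement shown accounts for the step. On these data alone, whether fluoro, bromo or methoxy at this position would lower the number further remains open, as does the effect of a dimethylamino group in place of the amine on the chloro compound.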